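This account rests on a few compounds, and the source may have more. Where it says the series, first, only, none or still open, it means among the compounds named here.

In a functional assay on HL-60 cells (Homo sapiens) for cytotoxicity, read by WST assay, with a stated time of 48 h (on this read-out lower numbers stand for an effect already at smaller amounts and higher numbers for an effect only at larger amounts of compound), compound 1 `O=C1OC[C@H](Cc2ccccc2)[C@H]1Cc1ccccc1O` gives 83000 nM and compound 2 `O=C1OC[C@H](Cc2ccccc2)[C@H]1Cc1ccc(OC(F)(F)F)cc1` gives 27000 nM as the lower of the two numbers, a gap beyond the usual scatter. Compound 3 `O=C1OC[C@H](Cc2ccccc2)[C@H]1Cc1ccc(Cl)cc1` has chloro in place of trifluoromethoxy on an aromatic carbon, para to a large group (chloro in place of trifluoromethoxy on an aromatic carbon). Among the measured compounds shown here, no measured pair shows this change, so the expectation rests on compound 2 alone. The expected step of a 1.1-fold higher number from compound 2 to compound 3 (0.05 log units; within the scatter) stays within the scatter, with no direction expected. The estimated value for compound 3 is 30000 nM with a range from 12000 nM to 75000 nM on this read-out.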

Compound 3, half-maximal effective concentration: 36000 nM
The estimate for compound 3 lay 1.2-fold (0.08 log units) below the measured number; the measured number falls inside the stated range.
By their numbers in this assay, from the lowest: compounds 2 and 3 (each within the scatter of the next); then compound 1.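

At this position, on an aromatic carbon para to a large group, chloro and trifluoromethoxy are not separated in this assay (a 1.3-fold higher number from compound 2 to compound 3 (0.12 log units; within the scatter)), even with 1 heavy atom in place of 5. The step (a 2.3-fold lower number from compound 1 to compound 3 (0.36 log units; beyond the scatter)) is modest and exchanges 4-chlorophenyl for 2-hydroxyphenyl, so the effects of the group and its place cannot be separated. No measured evidence accounts for either step. Open, going by these compounds, is how an amine or a carboxylic acid on this aromatic carbon would read out.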